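The source may hold more compounds than are shown below. What is called first, only, known or untested is meant among the compounds shown, and "the series" means these compounds.

In a functional assay on MDA-MB-231 cells (Homo sapiens) for inhibition, read by MTT assay, with a stated time of 72 h (a higher number here means a weaker inhibitor, a lower number a stronger inhibitor), compound 1 (`COc1ccccc1-c1csc2cnc(Nc3ccc(NC(=O)[C@@H]4CCCNC4)cc3)nc12`) gives 410 nM and compound 2 (`COc1ccccc1-c1csc2cnc(Nc3ccc(C(=O)NC4CCNCC4)cc3C)nc12`) gives 3240 nM as the higher of the two numbers, which makes compound 2 the weaker inhibitor by a gap beyond the scatter. Compound 3 (`COc1ccccc1-c1csc2cnc(Nc3ccc(C(=O)NC4CCNCC4)cc3C(F)(F)F)nc12`) departs from compound 2 in one place, with trifluoromethyl in place of methyl on an aromatic carbon, ortho to a large group and meta to a (piperidin-4-yl)carbamoyl group (trifluoromethyl in place of methyl on an aromatic carbon). Among the compounds with values here, no measured pair shows this exchange, and the two measured compounds differ from each other in more than one place, so the expectation has little direct support. In this assay no step beyond the scatter is expected (a 1.3-fold lower number from compound 2 to compound 3 (0.11 log units; within the scatter)). Compound 3 is expected at 2500 nM with 800 nM to 8000 nM as the estimated range.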

Compound 3, half-maximal inhibitory concentration: 2750 nM
For compound 3 the middle estimate is 1.1-fold (0.04 log units) below the measured one; the range from low to high includes it.
By their numbers in this assay, from the lowest: compound 1; then compounds 3 and 2 (each within the scatter of the next).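

In this assay trifluoromethyl in place of methyl on the aromatic carbon, ortho to a large group and meta to a (piperidin-4-yl)carbamoyl group, gives a 1.2-fold lower number from compound 2 to compound 3 (0.07 log units; within the scatter) and so does not set the two compounds apart. Within the data shown here, this is the first reading of a single exchange, as compound 1 and compound 2 differ in more than one place and offered no such step. No measurement shown here accounts for this result.

On these data alone, whether a different group at this position, such as a chlorine atom, an amine or a carboxylic acid, or plain hydrogen, would give a step beyond the scatter remains open. As far as these compounds go, compound 1 differs from compound 2 and compound 3 in more than one place, so which of those differences goes with its number also remains open.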